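Swapping the piperidine tail for a methylpiperazine

A few compounds are considered here, and "the series" means these few. Any claim that something is new, unique, unknown or untested is made for them only; others in the source may bear on it.

Two measured compounds share one core and differ only in the ring at the end of the amide chain. Compound 1 `COc1cc(N2CCN(C)CC2)ccc1Nc1ncc(Cl)c(Oc2cccc(NC(=O)CCN3CCCC3)c2)n1` carries a pyrrolidin-1-yl there, and in an ADME assay on 16HBE14o- cells (Homo sapiens) for antiproliferative activity, read by MTT assay, with a stated time of 72 h (a lower number here means a stronger inhibitor, a higher number a weaker inhibitor), compound 1 gives 1130 nM. Compound 2 `COc1cc(N2CCN(C)CC2)ccc1Nc1ncc(Cl)c(Oc2cccc(NC(=O)CCN3CCCCC3)c2)n1` carries a piperidin-1-yl instead, and in this assay compound 2 gives 970 nM. The change a 1.2-fold lower number from compound 1 to compound 2 (0.07 log units; within the scatter) shows that enlarging this ring by one carbon left the number essentially where it was, so compound 2 and compound 1 are not separable here.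

Compound 3 `COc1cc(N2CCN(C)CC2)ccc1Nc1ncc(Cl)c(Oc2cccc(NC(=O)CCN3CCN(C)CC3)c2)n1` is not yet measured. It differs from compound 2 by 4-methylpiperazin-1-yl in place of piperidin-1-yl on a saturated chain carbon, two bonds along the chain from a carbonyl carbon. Within the data shown here, the only measured step bearing on this tail, a 1.2-fold lower number from compound 1 to compound 2 (0.07 log units; within the scatter), was small, which suggests the tail can be varied without a large effect. Compound 3 is therefore expected to stay close to compound 2, with a step of a 1.1-fold higher number from compound 2 to compound 3 (0.05 log units; within the scatter) that does not clearly exceed the scatter. The estimate for compound 3 in this assay is 1100 nM, with a likely range from 500 nM to 2500 nM.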

Compound 3, half-maximal inhibitory concentration: 1750 nM
The estimate for compound 3 lay 1.6-fold (0.20 log units) below the measured number; the measured number falls inside the stated range.
By their numbers in this assay, from the lowest: compounds 2, 1 and 3 (each within the scatter of the next).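

In this assay the step is a 1.8-fold higher number from compound 2 to compound 3 (0.26 log units; within the scatter) when 4-methylpiperazin-1-yl replaces piperidin-1-yl and a 1.5-fold higher number from compound 1 to compound 3 (0.19 log units; within the scatter) when it replaces pyrrolidin-1-yl. Until now, the tail on a saturated chain carbon, two bonds along the chain from a carbonyl carbon, had been varied only by ring size, with one hetero atom in each ring; this change puts a second ring nitrogen, carrying a methyl group, at that place, and the three compounds still cannot be separated in this read-out. No other measurement on these compounds offers an explanation for these small steps.

The compounds shown leave open whether a morpholin-4-yl ring or an open-chain dimethylamino group at this place would also stay within the scatter of these three tails. Also open, on these data alone, is what a longer chain carrying the same rings would do, or a carboxylic acid in place of the ring amine, either of which might give a step large enough to read.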